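Swapping the amide ring on compound 3

A few compounds are considered here, and "the series" means these few. Any claim that something is new, unique, unknown or untested is made for them only; others in the source may bear on it.

Measured in an ADME assay on microsomes from liver (Mus musculus) for metabolic stability, read by mass spectrometry, with a stated time of 40 min, tested at 1 uM; on this read-out lower numbers stand for a less stable compound and higher numbers for a more stable compound:
- compound 1 `COc1cc(N2CCN(C(=O)N3CCN(C)CC3)CC2)ccc1Nc1nc(NC2CCCCC2)c2nc[nH]c2n1` gives 46%
- compound 2 `COc1cc(N2CCC(CC(=O)N3CCOCC3)CC2)ccc1Nc1nc(NC2CCCCC2)c2nc[nH]c2n1` gives 61%
- compound 3 `COc1cc(N2CCC(CC(=O)N3CCN(C)CC3)CC2)ccc1Nc1nc(NC2CCCCC2)c2nc[nH]c2n1` gives 43%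

Compound 3 gives 43% and compound 1 gives 46%, two numbers within the usual scatter of each other. Compound 2 stands clearly higher at 61% in the same test.

The next compound is compound 4 `COc1cc(N2CCC(CC(=O)N3CCCC3)CC2)ccc1Nc1nc(NC2CCCCC2)c2nc[nH]c2n1`, which carries pyrrolidin-1-yl in place of 4-methylpiperazin-1-yl on a carbonyl carbon.

Among the compounds with values here, one measured step bears on this change. It put 4-methylpiperazin-1-yl in place of morpholin-4-yl at the same place and gave a number 18 percentage points lower from compound 2 to compound 3 (beyond the scatter) in this assay. That modest step shows that the group on this carbonyl carbon can move the number, but it cannot say where pyrrolidin-1-yl will fall. No step beyond the scatter is therefore expected, and the estimated change is a number 5 percentage points higher from compound 3 to compound 4 (within the scatter) as a best guess. The estimated value for compound 4 is 48% (expected range 30% to 66%).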

Compound 4, percent of the compound remaining: 59%
Compound 4: the middle estimate sits 11 percentage points below what was measured; low and high end bracket the measured number.
By their numbers in this assay, from the lowest: compounds 3 and 1 (each within the scatter of the next); then compounds 4 and 2 (each within the scatter of the next).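

In this assay the change to pyrrolidin-1-yl gives a number 16 percentage points higher from compound 3 to compound 4 (beyond the scatter) and so adds a second step beyond the scatter away from 4-methylpiperazin-1-yl at this carbonyl carbon. Set against morpholin-4-yl, the same group gives a number 2 percentage points lower from compound 2 to compound 4 (within the scatter) and cannot be told apart from it, so two different rings here give matching numbers. Among these three groups, only 4-methylpiperazin-1-yl stands apart, and nothing available here explains that difference.

From the compounds shown here alone, it remains open whether the lower number goes with the methyl on the piperazine ring or with the ring itself. Piperazin-1-yl without that methyl, piperidin-1-yl, or an open-chain dimethylamino group on this carbonyl carbon would help separate these possibilities.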